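Compound 3 to compound 4: methyl to fluoro

The source may report more compounds than this note shows. Statements on the series, on what has been measured and on what is new or still open speak of the compounds shown alone.

Measured in a functional assay on MDA-MB-231 cells (Homo sapiens) for antiproliferative activity, read by MTT assay, with a stated time of 24 h (on this read-out lower numbers stand for stronger inhibition and higher numbers for weaker inhibition), so far:
- compound 1 `O=C(NNc1ccccc1F)c1ccccc1NS(=O)(=O)c1cnc(O)nc1O` gives > 20000 nM as a limit
- compound 2 `O=C(NNc1ccc(F)cc1)c1ccccc1NS(=O)(=O)c1cnc(O)nc1O` gives > 20000 nM as a limit
- compound 3 `Cc1ccc(C(=O)NNC(=O)c2ccccc2NS(=O)(=O)c2cnc(O)nc2O)cc1` gives > 20000 nM as a limit

Compound 3 has no number of its own and stands at the limit of > 20000 nM in this assay, at which 3 of the 3 values shown sit, with the other two.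

Compound 4 `O=C(NNC(=O)c1ccccc1NS(=O)(=O)c1cnc(O)nc1O)c1ccc(F)cc1` differs by fluoro in place of methyl on an aromatic carbon and is fluoro in place of methyl on an aromatic carbon, para to a large group.

The measured steps that bear on it are a step that the two limits leave unreadable from compound 1 to compound 3 and a step that the two limits leave unreadable from compound 2 to compound 3 and a step that the two limits leave unreadable from compound 1 to compound 2 and none gives a size.

No step beyond the scatter is expected in this assay because the limit of > 20000 nM in this assay, at which 3 of the 3 values shown sit, offers no sign of any change, and no direction is expected either.

The estimated step is a step that the limit leaves unreadable from compound 3 to compound 4 in this reading.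

Compound 4 is estimated at 25000 nM with an expected range from 10000 nM to 40000 nM and will probably be reported only as a limit.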

Compound 4, half-maximal inhibitory concentration: > 20000 nM
Compound 4 gave a limit, no number (the forecaster's own chance of this, stated with the estimate: 85%); the middle value lies beyond the limit too.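

In this assay compound 4 gives > 20000 nM, which is a limit. No new step can be read between compound 4 and compound 1, compound 2 or compound 3: the limit of > 20000 nM in this assay, at which 4 of the 4 values shown sit. The compounds shown leave open whether any member of this series reaches a measurable value in this assay.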